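From carboxy to methoxycarbonyl on the shared core

A few compounds are considered here, and "the series" means these few. Any claim that something is new, unique, unknown or untested is made for them only; others in the source may bear on it.

Compound 1 `CCOC(=O)c1ccc(-c2nn(-c3ccco3)c3ccccc23)cc1`: > 10000 nM
Compound 2 `CCCn1nc(-c2ccc(C(=O)OCC)cc2)c2ccccc21`: > 10000 nM
Compound 3 `O=C(O)c1ccc(-c2nn(Cc3ccccc3)c3ccccc23)cc1`: > 10000 nM

In a functional assay on cells (Platelet, Homo sapiens) for inhibition (a higher number here means a weaker inhibitor, a lower number a stronger inhibitor), every reading so far is a limit and not a number, namely (the limit of > 10000 nM in this assay, at which 3 of the 3 values shown sit). Compound 3 gives > 10000 nM, which is a limit.

Compound 4 `COC(=O)c1ccc(-c2nn(Cc3ccccc3)c3ccccc23)cc1` keeps the core of compound 3 and differs at the acid: methyl in place of hydrogen on an oxygen next to a carbonyl group. This is methyl in place of hydrogen on an oxygen next to a carbonyl group, or carboxy to methoxycarbonyl.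

Among the compounds with values here, only one measured step exists, a step that the two limits leave unreadable from compound 1 to compound 2. It lies at another place, on an aromatic nitrogen, and its size cannot be read, so it sets no size for this change. Compound 1 and compound 2 do carry an ester, but with other groups on that nitrogen. Within the data shown here, no measured compound joins an ester to the nitrogen group of compound 3, so that pairing is untested.

With compound 3 at the limit of > 10000 nM, a readable result could only lie towards stronger inhibition. The expected move is an at least 3.3-fold lower number from compound 3 to compound 4 (0.52 log units; beyond the scatter), a loose estimate, and another limit reading remains quite possible. The estimate for compound 4 is 3000 nM, with an expected range from 200 nM to 10000 nM.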

Compound 4, half-maximal inhibitory concentration: > 10000 nM
Compound 4: no number, only a limit (the forecaster's own chance of this, stated with the estimate: 40%); at least 3.3-fold (0.52 log units) between middle value and limit.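

In this assay compound 4 gives > 10000 nM, which is a limit and not a number. Compound 3 also stands at a limit, so the change from compound 3 to compound 4 cannot be read, and all readings share this position: the limit of > 10000 nM in this assay, at which 4 of the 4 values shown sit. The compounds shown leave open how strongly any of them inhibits, and whether the methyl group changes this.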